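Notes on compound 4 against three measured analogues

A few compounds are considered here, and "the series" means these few. Any claim that something is new, unique, unknown or untested is made for them only; others in the source may bear on it.

Measured so far in a functional assay on MCF7 cells (Homo sapiens) for cytotoxicity, read by MTT assay, with a stated time of 72 h; on this read-out lower numbers stand for an effect already at smaller amounts and higher numbers for an effect only at larger amounts of compound:
compound 1 `Cc1ccc2nc(Cl)c(/C=C3\C(=O)N(c4c(Cl)cccc4Cl)c4ccccc43)cc2c1C`: > 100 ug/mL, a limit of the assay.
compound 2 `Cc1ccc2nc(Cl)c(/C=C3\C(=O)N(c4c(Cl)cccc4Cl)c4ccccc43)cc2c1`: > 100 ug/mL, a limit of the assay.
compound 3 `CN(C)c1ccc(/C=C2\C(=O)N(c3c(Cl)cccc3Cl)c3ccccc32)cc1`: > 100 ug/mL, a limit of the assay.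

None of the three values in this assay is a number; all sit at the limit of > 100 ug/mL in this assay, at which 3 of the 3 values shown sit. Within the data shown here, the single measured step, a step that the two limits leave unreadable from compound 1 to compound 2, is therefore of unreadable size. Compound 3 stands at the limit together with the other two, so no order among the measured compounds can be read.

Compound 4 `O=C1/C(=C\c2ccc(Cl)cc2)c2ccccc2N1c1c(Cl)cccc1Cl` differs from compound 3 by chloro in place of dimethylamino on an aromatic carbon. Among the measured compounds shown here, no measured step bears on this change: the only step measured concerns hydrogen in place of methyl on an aromatic carbon, and its size could not be read. The expectation for compound 4 rests on the three limits alone. Because every measured compound sits at the limit of > 100 ug/mL in this assay, at which 3 of the 3 values shown sit, compound 4 is expected to lie near that limit too, with the step that the limit leaves unreadable from compound 3 to compound 4 expected to be no larger than the scatter in either direction.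

Compound 4 is estimated at 120 ug/mL, with a range from 40 ug/mL to 350 ug/mL in this assay, and most likely reported again only as a limit.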

Compound 4, concentration for half-maximal effect: 5 ug/mL
Compound 4: middle estimate off by 24-fold (1.38 log units), on the high side; the measured number lies below the stated range.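

In this assay, among these compounds, chloro in place of dimethylamino on an aromatic carbon, para to a large group, gives an at least 20-fold lower number from compound 3 to compound 4 (1.30 log units; beyond the scatter), the first readable step and evidence from this one pair that the substituent at this place can carry the read-out from the limit to a number. From the compounds shown here alone, compound 3 gives > 100 ug/mL, which is a limit and not a number, so the true size of the step remains unknown. Compound 4 is the only one of the four compounds with a numerical value, and the other three still share a single limit: the limit of > 100 ug/mL in this assay, at which 3 of the 4 values shown sit.

The compounds shown do not separate the effect of adding chloro from that of removing dimethylamino, and a series at this same place carrying hydrogen, fluoro, methoxy, a primary amine or a carboxylic acid would be needed to tell the two apart. Among the compounds shown here, whether the change from 4-(dimethylamino)phenyl to 4-chlorophenyl gives a step of similar size on any other core also stays open, as this single pair is the only comparison of its kind.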